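Nitro on the chloropyridine amide of the shared core

A few compounds are considered here, and "the series" means these few. Any claim that something is new, unique, unknown or untested is made for them only; others in the source may bear on it.

Compound 3, `O=C(Nc1cccc(-c2nc3ccccc3s2)c1)c1cccnc1Cl`, stands on the shared core with a chloropyridine amide. In an ADME assay on HepG2 cells (Homo sapiens) for inhibition, with a stated time of 72 h (a higher number here means that more compound is needed for the effect, a lower number that less compound is needed), compound 3 gives > 25000 nM, which is a limit of the assay and not a number. Compound 1, `C=C(C)C(=O)Nc1cccc(-c2nc3ccccc3s2)c1`, gives > 25000 nM in this assay, likewise a limit. Compound 2, `O=C(O)/C=C/C(=O)Nc1cccc(-c2nc3ccccc3s2)c1`, gives > 25000 nM in this assay, also a limit. The measured steps a step that the two limits leave unreadable from compound 1 to compound 2, a step that the two limits leave unreadable from compound 1 to compound 3 and a step that the two limits leave unreadable from compound 2 to compound 3 therefore carry no readable size because of the limit of > 25000 nM in this assay, at which 3 of the 3 values shown sit.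

Compound 4, `O=C(Nc1cccc(-c2nc3ccccc3s2)c1)c1cc([N+](=O)[O-])cnc1Cl`, differs from compound 3 by nitro in place of hydrogen on an aromatic carbon. Among the compounds with values here, no measured step bears on this change, and the three amide variations all end at the limit. For compound 4 the step that the limit leaves unreadable from compound 3 to compound 4 is expected to stay near that limit. Compound 4 is estimated at 30000 nM, with a range from 5000 nM to 150000 nM.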

Compound 4, half-maximal effective concentration: > 25000 nM
Compound 4: only a limit was reported (the forecaster's own chance of this, stated with the estimate: 75%); the middle value is on the limit's open side.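

The change from compound 3 to compound 4 gives no readable step, because both values are limits and not numbers: the limit of > 25000 nM in this assay, at which 4 of the 4 values shown sit.

The compounds shown leave open whether nitro in place of hydrogen changes the concentration needed in this assay.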